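A Sulfur-Bearing Replacement for the Compound 2 Group

This account rests on a few compounds, and the source may have more. Where it says the series, first, only, none or still open, it means among the compounds named here.

Compound 1 `O=C(NCc1ccc(S(=O)(=O)N2CCCCC2)cc1)c1cc2ccncc2[nH]1`: 1700 nM
Compound 2 `O=C(NCc1ccc(S(=O)(=O)N2CCCCC2)cc1)c1ccc2nc[nH]c2c1`: > 10000 nM (a limit)

In a functional assay on A2780 cells (Homo sapiens) for inhibition, read by sulforhodamine B assay, with a stated time of 72 h (on this read-out lower numbers stand for stronger inhibition and higher numbers for weaker inhibition), compound 2 gives > 10000 nM, which is a limit and not a number. Compound 3 `O=C(NCc1ccc(S(=O)(=O)N2CCCCC2)cc1)c1cc2cccnc2s1` differs from compound 2 by a group of 9 heavy atoms (7 carbon, 1 nitrogen, 1 sulfur; one five-membered aromatic ring with 1 hetero atom, one six-membered aromatic ring with 1 hetero atom) in place of a group of 9 heavy atoms (7 carbon, 2 nitrogen; one five-membered aromatic ring with 2 hetero atoms, one six-membered aromatic ring of carbon only), on a carbonyl carbon. Going by the values given here, one measured step bears on this: an at least 5.8-fold higher number from compound 1 to compound 2 (0.76 log units; beyond the scatter). That step left a group with one five-membered aromatic ring with 1 hetero atom and one six-membered aromatic ring with 1 hetero atom, and compound 3 restores these ring types. A moderate move to a lower number is therefore expected, though a second limit remains possible. The expected change is an at least 2.5-fold lower number from compound 2 to compound 3 (0.39 log units; beyond the scatter). For compound 3 the estimated value is 4000 nM, with an expected range of 800 nM to 15000 nM.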

Compound 3, half-maximal inhibitory concentration: > 10000 nM
Compound 3 gave a limit, no number (the forecaster's own chance of this, stated with the estimate: 40%); at least 2.5-fold (0.39 log units) between middle value and limit.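

In this assay, the ring types alone do not restore the level of compound 1: even with one five-membered aromatic ring with 1 hetero atom and one six-membered aromatic ring with 1 hetero atom on the carbonyl carbon, the result is an at least 5.8-fold higher number from compound 1 to compound 3 (0.76 log units; beyond the scatter). The step between compound 2 and compound 3 cannot be read, because both compounds give a limit and not a number: the limit of > 10000 nM in this assay, at which 2 of the 3 values shown sit.

On these data alone, it remains open whether an oxygen atom in place of the sulfur of compound 3, or an amine on the group of compound 1, would give a lower number.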